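Swapping the benzyl substituent: from methyl to chlorine

The source may hold more compounds than are shown below. What is called first, only, known or untested is meant among the compounds shown, and "the series" means these compounds.

Three compounds have been measured:
- compound 1 `CCSc1n[nH]c(-n2[se]c3ccccc3c2=O)n1`: 10000 nM
- compound 2 `Cc1ccc(CSc2n[nH]c(-n3[se]c4ccccc4c3=O)n2)cc1`: > 50000 nM
- compound 3 `Cc1cccc(CSc2n[nH]c(-n3[se]c4ccccc4c3=O)n2)c1`: 9040 nM

All three share one core and differ only in the group on a saturated chain carbon bound to a sulfur. In a functional assay on SMMC-7721 cells (Homo sapiens) for antiproliferative activity, read by CCK-8 assay, with a stated time of 48 h (on this read-out higher numbers stand for weaker inhibition and lower numbers for stronger inhibition), compound 1 gives 10000 nM. In this assay compound 2 reaches only the limit of > 50000 nM, a limit rather than a number (the limit of > 50000 nM in this assay, at which 1 of the 3 values shown sits). Compound 3 gives 9040 nM, the lowest of the two numbers, with compound 1 nearest, though the two sit within the usual scatter of each other (a 1.1-fold lower number from compound 1 to compound 3 (0.04 log units; within the scatter)).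

Compound 4 `O=c1c2ccccc2[se]n1-c1nc(SCc2ccc(Cl)cc2)n[nH]1` is not yet measured. It differs from compound 3 in one place: 4-chlorophenyl in place of 3-methylphenyl on a saturated chain carbon bound to a sulfur. The step that bears on this is an at least 5.5-fold lower number from compound 2 to compound 3 (0.74 log units; beyond the scatter), where moving the methyl from the 4-position of the phenyl to the 3-position brought the number down from a limit. Compound 4 returns a substituent to the 4-position, now chlorine instead of methyl. Its number is therefore expected to rise, by an estimated 3.3-fold higher number from compound 3 to compound 4 (0.52 log units; beyond the scatter), with a fair chance of landing at a limit again. The estimate for compound 4 is 30000 nM, with a range from 8000 nM to 100000 nM.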

Compound 4, half-maximal inhibitory concentration: 33900 nM
The estimate for compound 4 lay 1.1-fold (0.05 log units) below the measured number, and the stated range covers the measured number.
By their numbers in this assay, from the lowest: compounds 3 and 1 (each within the scatter of the next); then compound 4. At a limit, above all of these: compound 2.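

In this assay, a second group carrying its substituent at the 4-position now sits on the weak side of compound 3: a 3.8-fold higher number from compound 3 to compound 4 (0.57 log units; beyond the scatter), and against the methyl on the chain carbon the 4-chlorophenyl group also does worse: a 3.4-fold higher number from compound 1 to compound 4 (0.53 log units; beyond the scatter). Chloro in place of methyl on the 4-substituted ring gives a measurable number, an at least 1.4-fold lower number from compound 2 to compound 4 (0.16 log units; that floor lies within the scatter), but that floor does not separate the two substituents. Compound 2 gives a limit, not a number: the limit of > 50000 nM in this assay, at which 1 of the 4 values shown sits.

Compound 4 changes both the substituent and its place on the ring, so a 3-chlorophenyl group would be needed to tell these two changes apart. From the compounds shown here alone, how an unsubstituted phenyl or a longer alkyl chain would read at this position also stays open.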